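The source may report more compounds than this note shows. Statements on the series, on what has been measured and on what is new or still open speak of the compounds shown alone.

Working notes on the series. Compound 1 `CC1=NC(C)=C(C(=O)O)C(c2ccccc2[N+](=O)[O-])/C1=C(\O)OC/C=C/c1ccccc1` gives 37000 nM in a functional assay on IMR-32 cells for inhibition of Voltage-dependent N-type calcium channel subunit alpha-1B (Homo sapiens), read by calcium flux; on this read-out lower numbers stand for stronger inhibition and higher numbers for weaker inhibition. Within the data shown here, compound 2 `CC1=NC(C)=C(C(=O)O)C(c2cccc(C)c2)/C1=C(\O)OC/C=C/c1ccccc1` gives 1800 nM in this assay; the step of a 21-fold lower number from compound 1 to compound 2 (1.31 log units; beyond the scatter) is the only single-site change among the measured compounds. Compound 3 `CC1=NC(C)=C(C(=O)O)C(c2cccc(Cl)c2)/C1=C(\O)OC/C=C/c1ccc(Cl)cc1` gives 1500 nM in this assay; its number and that of compound 2 lie within the scatter of each other, and both stand far below compound 1, which has the highest number of the three.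

Compound 4 `CC1=NC(C)=C(C(=O)O)C(c2cccc(Cl)c2)/C1=C(\O)OC/C(C)=C/c1ccccc1` differs from compound 3 by 1-methyl-2-phenylethenyl in place of 2-(4-chlorophenyl)ethenyl on a saturated chain carbon bound to an oxygen on an unsaturated carbon. Among the measured compounds shown here, no measured step touches this part of the molecule: the one single-site step, a 21-fold lower number from compound 1 to compound 2 (1.31 log units; beyond the scatter), concerns the group on a saturated ring carbon, not the chain on the oxygen. Compound 2 and compound 3 differ at two places at once, one of them in this chain, and their values fall within the scatter of each other; that is the only indication available, and it gives no reason to expect a change here. Compound 4 is therefore expected to stay near compound 3, the step of no change at the digits printed from compound 3 to compound 4 (within the scatter) being estimated as not beyond the scatter. The number expected for compound 4 in this assay is 1500 nM, with a range from 500 nM to 4500 nM.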

Compound 4, half-maximal inhibitory concentration: 680 nM
Compound 4: middle estimate off by 2.2-fold (0.34 log units), on the high side, within the range that was stated.
By their numbers in this assay, from the lowest: compound 4; then compounds 3 and 2 (each within the scatter of the next); then compound 1.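

In this assay, the swap of 2-(4-chlorophenyl)ethenyl for 1-methyl-2-phenylethenyl on a saturated chain carbon bound to an oxygen on an unsaturated carbon gives a 2.2-fold lower number from compound 3 to compound 4 (0.34 log units; beyond the scatter), the only single-site step at this place among the compounds shown. The read-out therefore responds to this chain as well as to the group on a saturated ring carbon, although this step is modest beside a 21-fold lower number from compound 1 to compound 2 (1.31 log units; beyond the scatter). The change keeps the count of heavy atoms, the aromatic ring and the double bond outside it as they stand under the comparison, so the difference lies in the loss of the chlorine and the gain of the methyl, and no measurement available here accounts for the step.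

The step makes both of those changes at once, so the shares of the chlorine and the methyl cannot be separated, and a chain holding both, or the methyl alone on the 3-chlorophenyl compound, would be needed to divide them. As far as these compounds go, how an amine, a carboxylic acid or a longer chain would read at this place also stays open.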